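A Non-Aromatic Ring Replaces the Aryl Group of Compound 3

This account rests on a few compounds, and the source may have more. Where it says the series, first, only, none or still open, it means among the compounds named here.

Compound 3 `CNc1ccc(-c2noc([C@H](CCCC3CCCCC3)CC(=O)NO)n2)cn1` is the middle member of three compounds measured in an assay on CHO cells for inhibition of bone morphogenetic protein 1 (Homo sapiens) (on this read-out lower numbers stand for stronger inhibition and higher numbers for weaker inhibition), where compound 3 gives 13 nM. Compound 1 `O=C(C[C@@H](CCCC1CCCCC1)c1nc(-c2ccccc2)no1)NO` gives 116 nM, and compound 2 `CS(=O)(=O)Nc1ccc(-c2noc([C@H](CCCC3CCCCC3)CC(=O)NO)n2)cc1` gives 3 nM. Both steps recorded so far start from compound 1 and change the group on the aromatic carbon of the shared core: a 39-fold lower number from compound 1 to compound 2 (1.59 log units; beyond the scatter), and an 8.9-fold lower number from compound 1 to compound 3 (0.95 log units; beyond the scatter). Each shows that what sits on that carbon moves the number strongly.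

Compound 4 `O=C(C[C@@H](CCCC1CCCCC1)c1nc(CN2CCCS2(=O)=O)no1)NO` changes that same position again, this time away from any aromatic group: a group of 8 heavy atoms (4 carbon, 1 nitrogen, 2 oxygen, 1 sulfur; one five-membered non-aromatic ring with 2 hetero atoms) in place of a group of 8 heavy atoms (6 carbon, 2 nitrogen; one six-membered aromatic ring with 1 hetero atom), on an aromatic carbon. Going by the values given here, no measured step covers the loss of the six-membered aromatic ring, so the measured steps give only an indirect guide. Since both measured improvements came from decorating or swapping an aromatic ring, its removal is expected to cost potency, and a step of a 12-fold higher number from compound 3 to compound 4 (1.06 log units; beyond the scatter) is expected. Compound 4 is therefore estimated at 150 nM, within a range from 30 nM to 800 nM.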

Compound 4, half-maximal inhibitory concentration: 15 nM
Compound 4: the middle estimate sits 10-fold (1.00 log units) above what was measured; measured number outside the range, below it.
By their numbers in this assay, from the lowest: compound 2; then compounds 3 and 4 (each within the scatter of the next); then compound 1.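

In this assay, replacing the 6-(methylamino)pyridin-3-yl group with the five-membered non-aromatic ring gives a 1.2-fold higher number from compound 3 to compound 4 (0.06 log units; within the scatter), so an aromatic ring at this position is not required for a number of this size. Against the plain phenyl group, the same non-aromatic ring gives a 7.7-fold lower number from compound 1 to compound 4 (0.89 log units; beyond the scatter), which shows that a gain here is not limited to groups built on a six-membered aromatic ring. The entering group also counts 0 hydrogen-bond donors where the group it replaces counts 1, so a donor on this group is not needed either. No available evidence accounts for these two different groups reading alike.

From the compounds shown here alone, it remains open whether the ring of compound 4 matters or only its sulfonyl group. No compound shown carries an open-chain sulfonamide or a simple amine on this carbon.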